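Dichlorophenyl Variation in an Indole-Based Acrylic Acid Series

The source may report more compounds than this note shows. Statements on the series, on what has been measured and on what is new or still open speak of the compounds shown alone.

Measured compounds:
compound 1 `CC/C(=C(/c1ccc(/C=C/C(=O)O)cc1)c1cc2ccccc2[nH]1)c1ccccc1`, 108 nM
compound 2 `CC/C(=C(/c1ccc(/C=C/C(=O)O)cc1)c1cc2ccccc2[nH]1)c1ccc(C#N)cc1`, 278 nM
compound 3 `CC/C(=C(/c1ccc(/C=C/C(=O)O)cc1)c1cc2ccccc2[nH]1)c1cccc(F)c1C#N`, 40 nM

In a functional assay on MCF7 cells (Homo sapiens) for inhibition (on this read-out lower numbers stand for stronger inhibition and higher numbers for weaker inhibition), compound 1 stands second highest of the three numbers; it gives 108 nM, with compound 2 nearest at 278 nM and compound 3 furthest at 40 nM. Compound 4 `CC/C(=C(/c1ccc(/C=C/C(=O)O)cc1)c1cc2ccccc2[nH]1)c1cc(Cl)ccc1Cl` differs from compound 1 as follows: 2,5-dichlorophenyl in place of phenyl on a double-bonded chain carbon bound to a double-bonded chain carbon and a saturated chain carbon. For the measured compounds named here, two measured steps touch the same place. Substitution there moved the number both ways: a 2.6-fold higher number from compound 1 to compound 2 (0.41 log units; beyond the scatter) and a 2.7-fold lower number from compound 1 to compound 3 (0.43 log units; beyond the scatter). Neither bears a 2,5-dichlorophenyl, so the direction for compound 4 is open, and the expected step is a 1.1-fold lower number from compound 1 to compound 4 (0.03 log units; within the scatter). Compound 4 is therefore estimated at 100 nM, in a range from 30 nM to 350 nM.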

Compound 4, half-maximal inhibitory concentration: 71 nM
Estimate against measurement, compound 4: 1.4-fold (0.15 log units) above; the range from low to high includes it.
By their numbers in this assay, from the lowest: compounds 3, 4 and 1 (each within the scatter of the next, the first and the last beyond it); then compound 2.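

In this assay, the 2,5-dichlorophenyl group on this double-bonded chain carbon leaves compound 4 level with both the plain phenyl (a 1.5-fold lower number from compound 1 to compound 4 (0.18 log units; within the scatter)) and the 2-cyano-3-fluorophenyl (a 1.8-fold higher number from compound 3 to compound 4 (0.25 log units; within the scatter)). Only the 4-cyanophenyl stands apart (a 3.9-fold lower number from compound 2 to compound 4 (0.59 log units; beyond the scatter)), so a ring bearing two chlorines here reads with compounds 1 and 3, not with compound 2. Nothing at hand explains this.

Going by these compounds, whether a single chlorine would read the same stays open. So does the reading of a methoxy group or an amine on this ring.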